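Methyl for Cyclopropyl on a Sulfonyl Sulfur

The compounds below may be only part of what the source reports. "The series", "measured", "known", "first", "only" and "open" are said of these compounds alone.

In an ADME assay on a cell-free system (plasma, Homo sapiens) for protein binding (on this read-out lower numbers stand for a smaller free fraction and higher numbers for a larger free fraction), compound 1 `Cn1cc(-c2ccc(C(F)(F)F)cc2)c2cc(F)c(C(=O)NS(=O)(=O)C3CC3)cc21` gives 0.0025 and compound 2 `Cn1cc(-c2ccc(C(F)(F)F)cc2)c2ccc(C(=O)NS(=O)(=O)C3CC3)cc21` gives 0.002 as its value, so the two sit within the scatter of each other. Compound 3 `Cn1cc(-c2ccc(C(F)(F)F)cc2)c2cc(F)c(C(=O)NS(C)(=O)=O)cc21` has methyl in place of cyclopropyl on a sulfonyl sulfur. Going by the values given here, the one measured step is a 1.3-fold lower number from compound 1 to compound 2 (0.10 log units; within the scatter) with hydrogen in place of fluoro on an aromatic carbon, which leaves the sulfonyl group untouched and offers only indirect guidance. No step beyond the scatter is therefore expected in this assay in either direction. The estimate amounts to a 1.4-fold higher number from compound 1 to compound 3 (0.15 log units; within the scatter) as an expected step. Compound 3 is expected at 0.0035 with a range from 0.0018 to 0.007 as its estimate.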

Compound 3, unbound fraction: 0.002
For compound 3 the middle estimate is 1.8-fold (0.24 log units) above the measured one; low and high end bracket the measured number.
By their numbers in this assay, from the lowest: compounds 2, 3 and 1 (each within the scatter of the next).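

On the sulfonyl sulfur, methyl in place of cyclopropyl gives a 1.3-fold lower number from compound 1 to compound 3 (0.10 log units; within the scatter) in this assay, so for this pair, losing the three-membered ring leaves the two numbers within the scatter of each other. The earlier pair spoke only of fluoro and hydrogen on an aromatic carbon, while this pair is the one that speaks to the group on the sulfur. Nothing available explains this result.

On these data alone, whether a longer chain, a phenyl ring or a group carrying an amine or a carboxylic acid on the sulfonyl sulfur would give a step beyond the scatter remains open. So does whether methyl would behave the same way with hydrogen in place of fluoro on the aromatic carbon.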